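The source may hold more compounds than are shown below. What is called first, only, known or untested is meant among the compounds shown, and "the series" means these compounds.

Measured compounds and their values:
- Compound 1 `CCC(C)(C)Cc1c[nH]c(CCc2ccc(-n3ncnn3)cc2)n1` — in a functional assay on HEK293 cells for agonist activity at Bombesin receptor subtype-3 (Mus musculus), read by luminescence and calcium flux, with a stated time of 10 min (on this read-out higher numbers stand for an effect only at larger amounts of compound and lower numbers for an effect already at smaller amounts), compound 1 gives 99 nM.
- Compound 2 `CCC(C)(C)Cc1c[nH]c(CCc2ccc(-n3cccn3)cc2)n1` — in this assay compound 2 gives 113 nM.
- Compound 3 `CCC(C)(C)Cc1c[nH]c(CCc2ccc(-c3ccns3)cc2)n1` — in this assay compound 3 gives 103 nM.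

The three share one core and differ only in the small aromatic ring attached to the phenyl. Compound 3 sits within the scatter of both neighbours: the step of a 1.0-fold higher number from compound 1 to compound 3 (0.02 log units; within the scatter) and the step of a 1.1-fold lower number from compound 2 to compound 3 (0.04 log units; within the scatter) are each too small to count as a real change, as is a 1.1-fold higher number from compound 1 to compound 2 (0.06 log units; within the scatter). Swapping one five-membered ring for another has left the read-out unchanged.

Compound 4 `CCC(C)(C)Cc1c[nH]c(CCc2ccc(-c3cccnc3C(=O)O)cc2)n1` has not yet been measured in this assay. Its change from compound 3 is 2-carboxypyridin-3-yl in place of 1,2-thiazol-5-yl on an aromatic carbon. Unlike the measured steps, this brings in a six-membered ring that also carries a carboxylic acid, so none of the three steps speaks directly to it; they only show that this position tolerates a range of small rings without shifting the number. With no acid among the measured compounds, the outcome is uncertain, and a wide range is appropriate.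

Compound 4 is expected at 250 nM, with a range from 50 nM to 2000 nM. This estimate means an expected step of a 2.4-fold higher number from compound 3 to compound 4 (0.39 log units; beyond the scatter).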

Compound 4, half-maximal effective concentration: 97 nM
Compound 4: the middle estimate sits 2.6-fold (0.41 log units) above what was measured; the range from low to high includes it.
By their numbers in this assay, from the lowest: compounds 4, 1, 3 and 2 (each within the scatter of the next).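

Until now, only five-membered rings had been seen on this aromatic carbon, para to a large group. The 2-carboxypyridin-3-yl group extends that picture to a larger, six-membered aromatic ring carrying a carboxylic acid and a hydrogen-bond donor, and in this assay the replacement of 1,2-thiazol-5-yl gives a 1.1-fold lower number from compound 3 to compound 4 (0.03 log units; within the scatter) and the comparisons with the other two rings give a 1.2-fold lower number from compound 2 to compound 4 (0.07 log units; within the scatter) and a 1.0-fold lower number from compound 1 to compound 4 (0.01 log units; within the scatter) as the remaining steps, so all three stay within the scatter and this position accepts a clearly bigger group with a carboxylic acid without any real shift in the number. No measurement at hand offers an explanation for this result.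

The compounds shown do not separate the contribution of the carboxylic acid from that of the six-membered ring, since a plain pyridin-3-yl group without the acid is not among them. On these data alone, it also remains open whether the same flat response would hold for an amine, an amide or a longer chain on this aromatic carbon, or whether such groups would mark the limit of what the position accepts.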